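Ring nitrogen substituent variation in an acid ceramidase inhibitor series

A few compounds are considered here, and "the series" means these few. Any claim that something is new, unique, unknown or untested is made for them only; others in the source may bear on it.

Of the compounds shown here, three have been measured and a fourth awaits measurement. Compound 1 `CCCCCCNC(=O)n1cc(F)c(=O)n(C)c1=O` carries a methyl group on the ring nitrogen, compound 2 `CCCCCCNC(=O)n1cc(F)c(=O)n(CC)c1=O` an ethyl group, compound 3 `CCCCCCNC(=O)n1cc(F)c(=O)n(C(=O)OC)c1=O` a methoxycarbonyl group, and compound 4 `CCCCCCNC(=O)n1cc(F)c(=O)n(C(=O)OCC)c1=O` an ethoxycarbonyl group.

In an assay on HEK293 cells for inhibition of acid ceramidase (Rattus norvegicus), read by LC-MS, with a stated time of 30 min (on this read-out higher numbers stand for weaker inhibition and lower numbers for stronger inhibition), compound 1 gives 13 nM, compound 2 gives 18 nM, and compound 3 gives 7 nM. The step of a 1.4-fold higher number from compound 1 to compound 2 (0.14 log units; within the scatter) corresponds to methyl in place of hydrogen on a saturated chain carbon bound to an aromatic nitrogen. The step of a 1.9-fold lower number from compound 1 to compound 3 (0.27 log units; within the scatter) corresponds to methoxycarbonyl in place of methyl on an aromatic nitrogen. The step of a 2.6-fold lower number from compound 2 to compound 3 (0.41 log units; beyond the scatter) is the only one of the three that reaches beyond the scatter, and it is modest.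

Compound 4 differs from compound 3 by methyl in place of hydrogen on a saturated chain carbon bound to an oxygen next to a carbonyl group. Among the compounds with values here, this is the same kind of change as the one from compound 1 to compound 2, not the same change: in the earlier pair the methyl entered on a saturated chain carbon bound to an aromatic nitrogen, whereas here it enters on a saturated chain carbon bound to an oxygen next to a carbonyl group. The two cores differ by methoxycarbonyl in place of methyl on an aromatic nitrogen.

The step from compound 3 to compound 4 is expected to be small, a 1.3-fold higher number from compound 3 to compound 4 (0.11 log units; within the scatter), because a 1.4-fold higher number from compound 1 to compound 2 (0.14 log units; within the scatter) stayed within the scatter and nothing measured here points to a larger effect of adding a methyl on a chain carbon. Compound 4 is therefore expected to give about 9 nM in this assay, with a range from 4.5 nM to 20 nM.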

Compound 4, half-maximal inhibitory concentration: 12 nM
Compound 4: the middle estimate sits 1.3-fold (0.12 log units) below what was measured; low and high end bracket the measured number.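

The new step, a 1.7-fold higher number from compound 3 to compound 4 (0.23 log units; within the scatter), sits beside the earlier one on the core of compound 1, and in this assay the two do not differ: the same change on two cores in this assay, a 1.4-fold higher number (0.14 log units; within the scatter) from compound 1 to compound 2 and a 1.7-fold higher number (0.23 log units; within the scatter) from compound 3 to compound 4, 1.2-fold (0.09 log units) apart, within the scatter of two such steps

Across these two pairs, then, methyl in place of hydrogen carries from one core to the other without leaving the scatter, although the chain carbon is bound to an aromatic nitrogen in one pair and to an oxygen next to a carbonyl group in the other. This does not show a transferable effect of a given size, since neither step can be told from no change and two pairs say nothing about a third core; the exchanges that set the ethoxycarbonyl group against an alkyl group, a 1.5-fold lower number from compound 2 to compound 4 (0.18 log units; within the scatter) and a 1.1-fold lower number from compound 1 to compound 4 (0.03 log units; within the scatter), likewise stay within the scatter.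

Open, on these data alone, is whether a propyl or longer chain in place of the ethyl of the ethoxycarbonyl group, or an amine on that chain, would still give a step within the scatter. As far as these compounds go, all four compounds share the rest of the structure, so how these steps behave with any change elsewhere in it remains open.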